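Halogen swap on the aryl ring in two cationic series

The compounds below may be only part of what the source reports. "The series", "measured", "known", "first", "only" and "open" are said of these compounds alone.

Compound 1, `CN(C)c1ccc2c(=O)c(C(=O)Nc3cc(F)cc(F)c3)cn(-c3ccc(OCCCCCCC[N+]45CCN(CC4)CC5)cc3Cl)c2n1`: 80%
Compound 2, `CN(C)c1ccc2c(=O)c(C(=O)Nc3cc(F)cc(F)c3)cn(-c3ccc(OCCCCCCC[N+]45CCN(CC4)CC5)cc3F)c2n1`: 42.4%
Compound 3, `CN(C)c1ccc2c(=O)c(C(=O)Nc3cc(F)cc(F)c3)cn(-c3ccc(OCCCCCCC[n+]4ccccc4)cc3Cl)c2n1`: "not active" (no number reported)

In an assay on LX2 cells for inhibition of COL1A1 promoter (Homo sapiens), read by a luciferase reporter, with a stated time of 24 h, tested at 50 uM (a lower number here means a weaker effect, a higher number a stronger effect of the compound at the concentration tested), compound 1 gives 80%, while compound 2 gives 42.4%. The two differ only by fluoro in place of chloro on an aromatic carbon, and this change produced a number 37.6 percentage points lower from compound 1 to compound 2 (beyond the scatter).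

Compound 3 shares the core of compound 1 but carries a different cationic head on the chain: a group of 6 heavy atoms (5 carbon, 1 nitrogen; one six-membered aromatic ring with 1 hetero atom) in place of a group of 8 heavy atoms (6 carbon, 2 nitrogen; 2 six-membered non-aromatic rings with 2 hetero atoms each), on a saturated chain carbon, seven bonds along the chain from an oxygen on an aromatic ring. In this assay compound 3 gave no single number and was recorded as "not active" (no number reported).

Compound 4, `CN(C)c1ccc2c(=O)c(C(=O)Nc3cc(F)cc(F)c3)cn(-c3ccc(OCCCCCCC[n+]4ccccc4)cc3F)c2n1`, has not yet been measured. It differs from compound 3 by fluoro in place of chloro on an aromatic carbon, which is the same change as that from compound 1 to compound 2, at a place described in the same words.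

Since the step from compound 1 to compound 2 was a number 37.6 percentage points lower from compound 1 to compound 2 (beyond the scatter), the same change is expected to leave compound 4 no stronger than compound 3 in this assay, and compound 3 already gave no measurable effect. Compound 4 is therefore expected to sit near the bottom of the range, with an estimated 5%, between -10% and 25%, and there is a fair chance that this assay again reports only that it is not active rather than a number.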

Compound 4, a percentage reported as inhibition, at one concentration (the size of the read-out at that concentration, not a potency): "not active" (no number reported)
The entry for compound 4 holds no number, and the estimate cannot be compared.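

In this assay, going by these compounds alone, compound 3 is recorded as "not active" (no number reported) and compound 4 as "not active" (no number reported) so no step between the two can be read. The compounds shown leave open whether fluoro in place of chloro changes the effect at all when this six-membered aromatic head sits on the chain. Nothing measured here offers an explanation for the two entries.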